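A few compounds are considered here, and "the series" means these few. Any claim that something is new, unique, unknown or untested is made for them only; others in the source may bear on it.

Compound 1 `O=C(NCCCCc1ccccc1)n1c(=O)oc2cc(C3CCOCC3)ccc21` gives 68 nM in an assay on HEK293 cells for inhibition of acid ceramidase (Homo sapiens), read by fluorescence, with stated times of 10 min and 3 h (on this read-out lower numbers stand for stronger inhibition and higher numbers for weaker inhibition), the lowest of the two numbers recorded there. The nearest is compound 2 `CC(C)CNC(=O)n1c(=O)oc2ccc(C3CCN(C)CC3)cc21`, which in this assay gives 295 nM, a gap that lies beyond the usual scatter. Compound 3 `CC(=O)N1CCC(c2ccc3c(c2)oc(=O)n3C(=O)NCCCCc2ccccc2)CC1` has not yet been measured; it differs from compound 1 in one place: 1-acetylpiperidin-4-yl in place of oxan-4-yl on an aromatic carbon. Going by the values given here, no pair of measured compounds isolates this change. The expected step is small, no more than a modest loss, a 1.5-fold higher number from compound 1 to compound 3 (0.17 log units; within the scatter). Compound 3 is therefore estimated to give about 100 nM in this assay, within a range of 40 nM to 250 nM.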

Compound 3, half-maximal inhibitory concentration: 64 nM
Estimate against measurement, compound 3: 1.6-fold (0.19 log units) above, within the range that was stated.
By their numbers in this assay, from the lowest: compounds 3 and 1 (each within the scatter of the next); then compound 2.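

Going by these compounds alone, the step of a 1.1-fold lower number from compound 1 to compound 3 (0.03 log units; within the scatter) in this assay is the first reading of this change, and it shows that the aromatic carbon para to a fused ring tolerates 1-acetylpiperidin-4-yl in place of oxan-4-yl, with 9 heavy atoms entering for 6 and a double bond outside aromatic rings added. No data here explain this tolerance. Still open, as far as these compounds go, is whether an unacylated piperidine amine, a carboxylic acid or a longer chain on the same ring nitrogen or carbon would keep the number in this assay.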